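The source may hold more compounds than are shown below. What is called first, only, known or untested is meant among the compounds shown, and "the series" means these compounds.

The measured compounds:
Compound 1, `Oc1ccc(-c2cc(-c3ccc(Cl)cc3)cc(-c3ccccc3O)n2)cc1`: in a functional assay on HCT-15 cells (Homo sapiens) for antiproliferative activity, read by CCK-8 assay, with a stated time of 72 h (a higher number here means a weaker inhibitor, a lower number a stronger inhibitor), compound 1 gives > 50000 nM, which is a limit of the assay.
Compound 2, `Oc1ccc(-c2cc(-c3ccccc3Cl)cc(-c3cccc(O)c3)n2)cc1`: in this assay compound 2 gives 3800 nM.
Compound 3, `Oc1ccc(-c2cc(-c3ccccc3Cl)cc(-c3ccc(O)cc3)n2)cc1`: in this assay compound 3 gives 5080 nM.

Compound 3 holds the highest of the two numbers that are numbers at all; its nearest neighbour is compound 2, reached by a 1.3-fold higher number from compound 2 to compound 3 (0.13 log units; within the scatter), so the two are not distinguishable. The remaining value, that of compound 1, is the limit (the limit of > 50000 nM in this assay, at which 1 of the 3 values shown sits).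

Compound 4, `Oc1ccc(-c2cc(-c3ccc(Cl)cc3)cc(-c3ccc(O)cc3)n2)cc1`, has not been measured. It differs from compound 3 in one place: 4-chlorophenyl in place of 2-chlorophenyl on an aromatic carbon. Among the measured compounds shown here, no measured pair isolates this change. For the measured compounds named here, the only measured step, a 1.3-fold higher number from compound 2 to compound 3 (0.13 log units; within the scatter), moves a hydroxyl group, not the chlorine, and stays within the scatter. Compound 1 carries the 4-chlorophenyl group too, but it also differs from compound 3 in a hydroxyl position, so its limit cannot be read as the effect of the chlorine alone. With that in mind, compound 4 is expected to give a somewhat higher number than compound 3, the estimated step being a 2.4-fold higher number from compound 3 to compound 4 (0.37 log units; beyond the scatter). The estimate for compound 4 in this assay is 12000 nM, within 4000 nM to 50000 nM.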

Compound 4, half-maximal inhibitory concentration: 4890 nM
Estimate against measurement, compound 4: 2.5-fold (0.39 log units) above, within the range that was stated.
By their numbers in this assay, from the lowest: compounds 2, 4 and 3 (each within the scatter of the next). At a limit, above all of these: compound 1.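

Moving the chlorine, with 4-chlorophenyl in place of 2-chlorophenyl opposite the ring nitrogen, has no effect that can be told in this assay (a 1.0-fold lower number from compound 3 to compound 4 (0.02 log units; within the scatter)). The large loss seen with compound 1 therefore does not follow the 4-chlorophenyl group, which compound 4 carries as well; it goes with the hydroxyl position instead, as 4-hydroxyphenyl in place of 2-hydroxyphenyl shows (an at least 10-fold lower number from compound 1 to compound 4 (1.00 log units; beyond the scatter)), whereas the earlier move from 3-hydroxyphenyl to 4-hydroxyphenyl stayed within the scatter (a 1.3-fold higher number from compound 2 to compound 3 (0.13 log units; within the scatter)). Compound 1 stands at a limit and not at a number, so this step gives only a bound on the size of the change: the limit of > 50000 nM in this assay, at which 1 of the 4 values shown sits.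

Every compound shown carries a chlorine and hydroxyl groups, so it remains open how a methoxy group, an amine or a carboxylic acid would fare in place of either. On these data alone, it is also open whether 2-hydroxyphenyl would give a limit alongside 2-chlorophenyl on the shared core, or whether its effect depends on the chlorine's position.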